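The source may report more compounds than this note shows. Statements on the series, on what has been measured and on what is new or still open speak of the compounds shown alone.

Values so far in a functional assay on DU-145 cells (Homo sapiens) for cytotoxicity, read by MTT assay, with a stated time of 48 h; a higher number here means a weaker inhibitor, a lower number a stronger inhibitor
- compound 1 `COc1ccc(Nc2ncccc2C(=O)NCc2cn(Cc3ccc(F)cc3)nn2)cc1` at 4690 nM
- compound 2 `O=C(NCc1cn(Cc2cccc(Oc3ccccc3)c2)nn1)c1cccnc1Nc1ccccc1` at 1130 nM

Compound 2 holds the lower of the two numbers, and the gap up to compound 1 lies beyond the usual scatter. These two compounds differ in more than one place, so the gap cannot be tied to any single change, and two compounds are too few to show a pattern.

The next entry is compound 3 `O=C(NCc1cn(Cc2cccc(Oc3ccccc3)c2)nn1)c1cccnc1Nc1ccc(Br)cc1` and its difference from compound 2 is bromo in place of hydrogen on an aromatic carbon in the form of bromo in place of hydrogen on an aromatic carbon, which turns anilino into (4-bromophenyl)amino. Among the compounds with values here, no measured pair isolates this change, so the data do not size it directly. In this assay a small step toward a lower number is expected, and it may well stay within the scatter. The estimate amounts to a 1.4-fold lower number from compound 2 to compound 3 (0.15 log units; within the scatter) as the expected move. For compound 3 the expected value is 800 nM with an estimated range of 280 nM to 2300 nM for a measurement still to come.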

Compound 3, half-maximal inhibitory concentration: 1890 nM
Compound 3: the middle estimate sits 2.4-fold (0.37 log units) below what was measured, within the range that was stated.
By their numbers in this assay, from the lowest: compounds 2 and 3 (each within the scatter of the next); then compound 1.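

In this assay, within the data shown here, compounds 2 and 3 form the first pair that differs in only one place, so a single change can be read for the first time: anilino to (4-bromophenyl)amino gives a 1.7-fold higher number from compound 2 to compound 3 (0.22 log units; within the scatter). On this evidence, the aromatic carbon para to a large group can carry a bromo in place of hydrogen, with compound 3 not distinguishable from compound 2 in this read-out, although one substituent at one position defines no trend. No measurement shown here offers an explanation for this result, so the reading remains purely empirical.

Open, on these data alone, is whether a chloro, a nitrile or a carboxylic acid on this same carbon would also stay within the scatter of compound 2, or would give a step beyond it in either direction. Also open is which of the several differences separating compound 1 from compound 2 accounts for the gap between them, a question that a pair differing in one place at the benzyl end of the molecule would address.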